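From 2,3-Dihydroxypropyl to 3-Hydroxypropyl

The source may report more compounds than this note shows. Statements on the series, on what has been measured and on what is new or still open speak of the compounds shown alone.

Of the compounds shown here, three have been measured in a physicochemical assay for lipophilicity, measured as octanol-water partition; a lower number here means a more polar compound, a higher number a more lipophilic compound. Compound 1 `Cc1ccccc1OCC(C)O` gives 2.14, compound 3 `CC(O)COc1c(Cl)cccc1Cl` gives 2.64, and compound 2 `Cc1cc(Cl)cc(C)c1OCC(O)CO` gives 2.76. Compound 2 carries the highest of the three numbers, but its nearest neighbour is compound 3, whose number lies within the scatter of it, so the two cannot be ranked against each other. Compound 1 stands furthest from compound 2, with a number that is lower by more than the scatter allows.

The next compound, compound 4 `Cc1cc(Cl)cc(C)c1OCCCO`, is drawn from compound 2 by one change: hydrogen in place of hydroxy on a saturated chain carbon bound to two saturated chain carbons That is, the 2,3-dihydroxypropyl chain of compound 2 becomes a 3-hydroxypropyl chain in compound 4, and the rest of the molecule is untouched. Among the measured compounds shown here, no measured pair in this set shows this exact change, so its size has to be judged from the structures alone.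

In this assay the step from compound 2 to compound 4 is expected to be upward and clearly beyond the scatter, estimated at a number 0.74 log units higher from compound 2 to compound 4 (beyond the scatter). Compound 4 is therefore expected to give about 3.5 in this assay, with a likely range from 3.1 to 3.9.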

Compound 4, partition coefficient: 3.72
The estimate for compound 4 lay 0.22 log units below the measured number, within the range that was stated.
By their numbers in this assay, from the lowest: compound 1; then compounds 3 and 2 (each within the scatter of the next); then compound 4.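

Hydrogen in place of hydroxy on a saturated chain carbon bound to two saturated chain carbons now has a measured size in this assay: a number 0.96 log units higher from compound 2 to compound 4 (beyond the scatter). Among the compounds shown here, the earlier compounds offered no pair differing in one place, so this is the first step in the set that isolates a single change, and it shows that this position on the chain is not silent in this assay, since the 2,3-dihydroxypropyl to 3-hydroxypropyl change carries the number past the scatter. Nothing measured here bears on why the step has this size.

The compounds shown leave open what an amine or a fluorine on this same saturated chain carbon would give in this assay, and where a longer chain in place of the 3-hydroxypropyl chain would put the number. For the compounds shown here, with only one pair to go on, they also leave open whether the same change gives a step of similar size on a different core, or whether this step belongs to the core of compound 2 alone.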